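Chloro in Place of Bromo: Cytotoxicity Stays Beyond Reach

The compounds below may be only part of what the source reports. "The series", "measured", "known", "first", "only" and "open" are said of these compounds alone.

Compound 1 `O=[N+]([O-])c1cc(CSc2nnc(-c3ccc(Cl)cc3)n2Cc2ccccc2)cc([N+](=O)[O-])c1`: in an ADME assay on A-431 cells (Homo sapiens) for cytotoxicity, with a stated time of 48 h (a higher number here means a weaker inhibitor, a lower number a stronger inhibitor), compound 1 gives > 30000 nM, which is a limit of the assay and not a number.
Compound 2 `O=[N+]([O-])c1cc(CSc2nnc(-c3ccc(Br)cc3)n2Cc2ccccc2)cc([N+](=O)[O-])c1`: in this assay compound 2 gives > 30000 nM, again a limit rather than a number.
Compound 3 `O=[N+]([O-])c1cc(-c2nnc(SCc3ccc(Br)cc3)n2Cc2ccccc2)cc([N+](=O)[O-])c1`: in this assay compound 3 gives > 30000 nM, also only a limit.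

The change from compound 2 to compound 1 is chloro in place of bromo on an aromatic carbon. The size of that step, a step that the two limits leave unreadable from compound 2 to compound 1, cannot be read because of the limit of > 30000 nM in this assay, at which 3 of the 3 values shown sit. Compound 3 is built from the same atoms as compound 2, joined differently; the difference between the two cores is not broken down here.

Compound 4 `O=[N+]([O-])c1cc(-c2nnc(SCc3ccc(Cl)cc3)n2Cc2ccccc2)cc([N+](=O)[O-])c1` has not been measured. Among the compounds with values here, it differs from compound 3 by chloro in place of bromo on an aromatic carbon, the same change as the one from compound 2 to compound 1, made at a place described in the same words. Because (the limit of > 30000 nM in this assay, at which 3 of the 3 values shown sit), the step that the limit leaves unreadable from compound 3 to compound 4 is expected to be small and unreadable. The value of compound 4 in this assay is therefore estimated at 50000 nM, most probably reported as a limit again.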

Compound 4, half-maximal inhibitory concentration: > 30000 nM
Compound 4: no number, only a limit; the forecaster's own chance of this, stated with the estimate: 85%; the middle value does not contradict the limit.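

In this assay compound 4 gives > 30000 nM, which is a limit of the assay and not a number. No size can be read for the step between compound 3 and compound 4, because the values share one limit: the limit of > 30000 nM in this assay, at which 4 of the 4 values shown sit. The compounds shown leave open whether chloro and bromo, or the two cores, differ at all in this assay.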